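The compounds below may be only part of what the source reports. "The series", "measured", "known", "first", "only" and "open" are said of these compounds alone.

Compound 3 `CN1CCC(NC(=O)c2ccc(Nc3ncc(Br)c(NC4CCCC4)n3)cc2)CC1` gives the lowest of the three numbers measured in a functional assay on A549 cells (Homo sapiens) for cytotoxicity, read by MTT assay, with a stated time of 48 h (on this read-out higher numbers stand for weaker inhibition and lower numbers for stronger inhibition), namely 500 nM. Compound 1 `CN1CCC(NC(=O)c2ccc(Nc3ncc([N+](=O)[O-])c(NC4CCCC4)n3)cc2)CC1` gives 42300 nM in this assay, and compound 2 `CN1CCN(c2ccc(Nc3ncc(F)c(NC4CCCC4)n3)cc2)CC1` gives 37200 nM. Compound 4 `CN1CCC(NC(=O)c2ccc(Nc3ncc(F)c(NC4CCCC4)n3)cc2)CC1` differs from compound 3 by fluoro in place of bromo on an aromatic carbon. Within the data shown here, the one measured step at this carbon is an 85-fold lower number from compound 1 to compound 3 (1.93 log units; beyond the scatter), which shows that the group here moves the number strongly. Among the measured compounds shown here, no measured step exchanges bromo for fluoro directly; compound 2, which carries fluoro on a different core, sits far above compound 3. Compound 4 is therefore expected to give a clearly higher number than compound 3, a step estimated at a 30-fold higher number from compound 3 to compound 4 (1.48 log units; beyond the scatter). The estimate for compound 4 in this assay is 15000 nM, with a range from 3000 nM to 60000 nM.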

Compound 4, half-maximal inhibitory concentration: 10300 nM
Beside the measured number, compound 4's estimate is 1.5-fold (0.16 log units) above it; measured number inside the range.
By their numbers in this assay, from the lowest: compound 3; then compound 4; then compounds 2 and 1 (each within the scatter of the next).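

In this assay, the choice of halogen on this aromatic carbon matters on its own, with the core held fixed: the exchange of bromo for fluoro gives a 21-fold higher number from compound 3 to compound 4 (1.31 log units; beyond the scatter). Fluoro still improves on nitro, but only by a modest step (a 4.1-fold lower number from compound 1 to compound 4 (0.61 log units; beyond the scatter)), far smaller than the step from nitro to bromo. With fluoro held constant, the side group also counts, modestly (a 3.6-fold lower number from compound 2 to compound 4 (0.56 log units; beyond the scatter)). No measurement given here explains these differences. From the compounds shown here alone, whether chloro, methyl or an amine on this carbon would fall nearer compound 3 or compound 4 remains open.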